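Solubility notes: from compound 2 to compound 4

The source may hold more compounds than are shown below. What is called first, only, known or untested is meant among the compounds shown, and "the series" means these compounds.

In a physicochemical assay for solubility, with a stated time of 3 days, at pH 2 (on this read-out lower numbers stand for lower solubility and higher numbers for higher solubility), compound 1 (`NC(=O)c1ccc2[nH]c(-c3ccc(OC4CCCNC4)cc3)nc2c1`) gives > 400000 nM as a limit of the assay. Compound 2 (`NC(=O)c1ccc2[nH]c(-c3ccc(OCC4CCNCC4)cc3)nc2c1`) gives > 400000 nM and this too is a limit. For compound 3 (`NC(=O)c1ccc2[nH]c(-c3ccc(OCC4CCN(Cc5ccc(Cl)c(Cl)c5)CC4)cc3)nc2c1`) the entry reads "not determined" (no result reported) and carries no number. The only anchor is the limit of > 400000 nM in this assay, at which 2 of the 3 values shown sit, and compound 2 has no exact value. Compound 4 (`CC(=O)N1CCC(CCOc2ccc(-c3nc4cc(C(N)=O)ccc4[nH]3)cc2)CC1`) follows from (1-acetylpiperidin-4-yl)methyl in place of piperidin-4-yl on a saturated chain carbon bound to an oxygen on an aromatic ring and swaps the free piperidine for the acetylated one. Among the measured compounds shown here, the one measured step, a step that the two limits leave unreadable from compound 1 to compound 2, gives no size to carry over, so the expectation rests on the structural change alone. A downward move is expected, estimated as an at least 10-fold lower number from compound 2 to compound 4 (1.00 log units; beyond the scatter) in this assay with wide uncertainty. Compound 4 is estimated at 40000 nM (range 5000 nM to 400000 nM) in this assay.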

Compound 4, solubility: 87000 nM
The estimate for compound 4 lay 2.2-fold (0.34 log units) below the measured number; measured number inside the range.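

In this assay, the change to (1-acetylpiperidin-4-yl)methyl in place of piperidin-4-yl on a saturated chain carbon bound to an oxygen on an aromatic ring gives an at least 4.5-fold lower number from compound 2 to compound 4 (0.66 log units; beyond the scatter). Among the compounds shown here, the earlier step between compound 1 and compound 2 cannot be read, which leaves this as the only step with a size. That size is only a bound because compound 2 stands at a limit: the limit of > 400000 nM in this assay, at which 2 of the 4 values shown sit.

Going by these compounds, how much of the step belongs to the acetyl group stays open. Also open, on these data alone, is how a methanesulfonyl or propanoyl group in place of the acetyl would read.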